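The compounds below may be only part of what the source reports. "The series", "measured", "known", "first", "only" and "open" are said of these compounds alone.

Measured so far in an ADME assay on HEK293 cells (Homo sapiens) for cytotoxicity, read by CCK-8 assay and cell counting, with a stated time of 2 days; a lower number here means a stronger inhibitor, a higher number a weaker inhibitor:
compound 1 `Oc1ccc(-c2cc(-c3cccc(Cl)c3)nc(-c3ccccn3)c2)cc1`: 25400 nM
compound 2 `Oc1ccc(-c2cc(-c3ccc(Cl)cc3)nc(-c3ccccn3)c2)cc1`: 27200 nM

On these two numbers compound 1 stands lowest, with compound 2 nearest, the step of a 1.1-fold higher number from compound 1 to compound 2 (0.03 log units; within the scatter) not separating the two. Compound 3 `Oc1ccc(-c2cc(-c3ccccc3)nc(-c3cccc(Cl)c3)c2)cc1` is the unmeasured member; it differs from compound 1 by phenyl in place of pyridin-2-yl on an aromatic carbon.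

Among the compounds with values here, only one measured step exists, a 1.1-fold higher number from compound 1 to compound 2 (0.03 log units; within the scatter), and it concerns 4-chlorophenyl in place of 3-chlorophenyl, not the exchange of pyridin-2-yl for phenyl. Within the data shown here, no measured step bears directly on the change from compound 1 to compound 3. Among the measured compounds shown here, with the single step on record lying within the scatter and nothing in the data pointing to a shift in either direction, the expectation for compound 3 in this assay is a step of about a 1.2-fold lower number from compound 1 to compound 3 (0.06 log units; within the scatter), that is no step beyond the scatter. Compound 3 is accordingly estimated at 22000 nM, with a range of 9000 nM to 55000 nM.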

Compound 3, half-maximal inhibitory concentration: 2820 nM
Compound 3: the middle estimate sits 7.8-fold (0.89 log units) above what was measured; the measured number lies below the stated range.
By their numbers in this assay, from the lowest: compound 3; then compounds 1 and 2 (each within the scatter of the next).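

In this assay, the exchange at the aromatic carbon next to the ring nitrogen gives a clear change, with phenyl in place of pyridin-2-yl producing a 9.0-fold lower number from compound 1 to compound 3 (0.95 log units; beyond the scatter). This place in the series therefore responds to its substituent, whereas moving the chlorine on the chlorophenyl group gave only a 1.1-fold higher number from compound 1 to compound 2 (0.03 log units; within the scatter), which did not separate those two compounds. The exchange removes the ring nitrogen and the one hydrogen-bond acceptor counted for pyridin-2-yl, but no accompanying measurement explains the size of the step.

From the compounds shown here alone, whether the same exchange would give a similar step with the 4-chlorophenyl group of compound 2 remains open. Also open, going by these compounds, is how an amine, a carboxylic acid or a longer alkyl chain on the phenyl ring of compound 3 would read in this assay.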